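Working notes: the step from compound 3 to compound 4

The compounds below may be only part of what the source reports. "The series", "measured", "known", "first", "only" and "open" are said of these compounds alone.

In an ADME assay on BaF3 cells (Mus musculus) for antiproliferative activity, read by CCK-8 assay, with a stated time of 72 h (on this read-out higher numbers stand for weaker inhibition of growth and lower numbers for stronger inhibition of growth), compound 1 `CNC(=O)CCSc1ccc2c(/C=C/c3ccccn3)n[nH]c2c1` reads > 10000 nM, which is a limit of the assay. Compound 2 `Cc1cccc(NC(=O)CCSc2ccc3c(/C=C/c4ccccn4)n[nH]c3c2)c1` reads > 10000 nM, again a limit. Going by the values given here, compound 3 `Cc1ccc(NC(=O)CCSc2ccc3c(/C=C/c4ccccn4)n[nH]c3c2)cc1C(F)(F)F` gives 530 nM, the only actual number in the set, and it stands well clear of the limit of > 10000 nM in this assay, at which 2 of the 3 values shown sit. Its two steps are large and beyond the scatter: an at least 18-fold lower number from compound 1 to compound 3 (1.27 log units; beyond the scatter) and an at least 18-fold lower number from compound 2 to compound 3 (1.27 log units; beyond the scatter). The remaining step, a step that the two limits leave unreadable from compound 1 to compound 2, carries no size.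

Compound 4 `Cc1cn(Cc2ccc(NC(=O)CCSc3ccc4c(/C=C/c5ccccn5)n[nH]c4c3)cc2C(F)(F)F)cn1` keeps all of compound 3 and changes one place: 4-methyl-1H-imidazol-1-yl in place of hydrogen on a saturated chain carbon bound to an aromatic carbon. Read one bond further out, this is methyl to (4-methyl-1H-imidazol-1-yl)methyl. Among the compounds with values here, no measured step tests a change at this place, so the evidence is indirect. The substituent on the amide nitrogen is the only part varied so far, and changing it gave an at least 18-fold lower number from compound 2 to compound 3 (1.27 log units; beyond the scatter). Compound 4 changes that same substituent while retaining the trifluoromethyl group of compound 3. A moderate shift toward stronger inhibition of growth is therefore expected, smaller than the measured steps, though no change beyond the scatter remains possible. The expected step is a 2.7-fold lower number from compound 3 to compound 4 (0.42 log units; beyond the scatter). The estimate for compound 4 is 200 nM, with an expected range of 40 nM to 1000 nM.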

Compound 4, concentration for 50% growth inhibition: 1990 nM
Compound 4: the middle estimate sits 10-fold (1.00 log units) below what was measured, outside the stated range (above it).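

In this assay, going by these compounds alone, the first change at the saturated chain carbon bound to an aromatic carbon runs toward weaker inhibition of growth: adding 4-methyl-1H-imidazol-1-yl in place of hydrogen gives a 3.8-fold higher number from compound 3 to compound 4 (0.57 log units; beyond the scatter). Within the data shown here, the earlier steps varied the whole substituent on the amide nitrogen, whereas this one keeps the trifluoromethyl group and alters only this carbon, so it gives the first direct reading at this position, and that reading is a modest loss beyond the scatter. The position still accepts an added group of 6 heavy atoms, one five-membered aromatic ring among them, and compound 4 remains a measured number rather than joining the compounds that stand at a limit of the assay: the limit of > 10000 nM in this assay, at which 2 of the 4 values shown sit.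

With a single group shown at this carbon, it remains open whether the loss belongs to the ring itself, to its methyl, or to any addition at this place. A dimethylamino group or a carboxylic acid at the same carbon, or the same ring on a longer chain, would show whether the step depends on the nature of the group or on the distance of the ring from the aromatic carbon.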